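Acetyl in place of methyl: the step to compound 4

A few compounds are considered here, and "the series" means these few. Any claim that something is new, unique, unknown or untested is made for them only; others in the source may bear on it.

Measured so far:
compound 1 `Cc1nc(Nc2ccc(F)cc2)c2cc[nH]c2n1` — 372000000 nM
compound 2 `Cc1nc(Nc2ccc(I)cc2)c2cc[nH]c2n1` — 219000000 nM
compound 3 `Cc1ccc(Nc2[nH]c(C)nc3nccc2-3)cc1` — 759000000 nM

In a functional assay on the whole organism for inhibition, with Nicotiana tabacum as the target (a lower number here means a stronger inhibitor, a higher number a weaker inhibitor), compound 3 gives 759000000 nM, the highest of the three numbers. Compound 1 stands at 372000000 nM and compound 2 at 219000000 nM; both gaps to compound 3 lie beyond the scatter, so compound 3 is the weakest inhibitor of the three as measured. Among the measured compounds shown here, the only step between compounds that differ in one place is a 1.7-fold lower number from compound 1 to compound 2 (0.23 log units; within the scatter), an exchange of one halogen for another on the six-membered ring, and it stays within the scatter.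

Compound 4 `CC(=O)c1ccc(Nc2[nH]c(C)nc3nccc2-3)cc1` differs from compound 3 by acetyl in place of methyl on an aromatic carbon. For the measured compounds named here, no measured step concerns a carbonyl or an acetyl; the single step that can be drawn on, a 1.7-fold lower number from compound 1 to compound 2 (0.23 log units; within the scatter), shows only that one substituent swap at the same kind of place gave no movement beyond the scatter. On that basis no step beyond the scatter is expected in this assay, though the range must be kept wide.

Compound 4 is expected to give about 600000000 nM in this assay, between 200000000 nM and 2000000000 nM. The expected step is therefore a 1.3-fold lower number from compound 3 to compound 4 (0.10 log units; within the scatter), within the scatter.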

Compound 4, half-maximal inhibitory concentration: 646000000 nM
Beside the measured number, compound 4's estimate is 1.1-fold (0.03 log units) below it, and the stated range covers the measured number.
By their numbers in this assay, from the lowest: compounds 2, 1, 4 and 3 (each within the scatter of the next, the first and the last beyond it).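

In this assay, acetyl in place of methyl on an aromatic carbon, para to a large group, gives a step that stays within the scatter (a 1.2-fold lower number from compound 3 to compound 4 (0.07 log units; within the scatter)), so this position takes a group of 3 heavy atoms with a carbonyl and a hydrogen-bond acceptor with no movement that can be read. Among the compounds shown here, the only earlier step between compounds differing in one place, iodo in place of fluoro on an aromatic carbon (a 1.7-fold lower number from compound 1 to compound 2 (0.23 log units; within the scatter)), was a swap of one halogen for another, and the new step extends the same flat reading to a change of a different kind, though still on two compounds' worth of evidence for each type of change. Nothing measured alongside these numbers bears on the result, and no reason for it can be offered.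

From the compounds shown here alone, whether this position stays as flat for an amine, a carboxylic acid or a longer chain remains open, since any of these could still give a step beyond the scatter. Also open is whether acetyl in place of methyl gives the same result in other assays, as the compounds shown are compared in this assay alone.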